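The compounds below may be only part of what the source reports. "The series", "measured", "known", "first", "only" and "open" are said of these compounds alone.

Measured so far in a functional assay on HL-60 cells (Homo sapiens); on this read-out lower numbers stand for an effect already at smaller amounts and higher numbers for an effect only at larger amounts of compound:

- compound 1, `COc1cc(/C=C\c2ccc(O[Si](C)(C)C(C)(C)C)cc2)cc(OC)c1`: > 200000 nM
- compound 2, `COc1cc(/C=C/c2ccc(N)cc2)cc(OC)c1`: 15000 nM
- compound 3, `COc1cc(/C=C\c2ccc(O)c(O)c2)cc(OC)c1`: 100 nM

Compound 1 gives no number in this assay, only a limit, > 200000 nM; (the limit of > 200000 nM in this assay, at which 1 of the 3 values shown sits). Among the two compounds with a real number, compound 3 stands lowest: compound 2 sits at a markedly higher number, a gap well beyond the usual scatter of this assay. Compound 3 therefore is the reference point of the step followed here.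

The next compound, compound 4, `COc1cc(/C=C/c2ccc(O)c(O)c2)cc(OC)c1`, has not been measured yet. Compared with compound 3 the change is the two compounds have the same atoms and bonds and differ only in configuration as drawn: 1 of 1 stereo elements differ; a double bond is drawn Z in compound 3 and E in compound 4. Going by the values given here, no pair of already measured compounds differs in just this way, so the size of the step cannot be read off directly. Among the compounds with values here, compound 2, the only other compound with a number, carries the double bond drawn E and gives 15000 nM, while compound 3 with the double bond drawn Z gives 100 nM; the two differ in more than the double bond, so this is only a loose hint.

On that basis compound 4 is expected to need a larger amount than compound 3, a step of about a 50-fold higher number from compound 3 to compound 4 (1.70 log units; beyond the scatter). The estimate for compound 4 in this assay is 5000 nM, with a likely range from 500 nM to 50000 nM.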

Compound 4, concentration for half-maximal activity: 1000 nM
For compound 4 the middle estimate is 5.0-fold (0.70 log units) above the measured one; the range from low to high includes it.
By their numbers in this assay, from the lowest: compound 3; then compound 4; then compound 2. At a limit, above all of these: compound 1.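

In this assay, changing the double bond from Z to E gives a 10-fold higher number from compound 3 to compound 4 (1.00 log units; beyond the scatter). Going by these compounds alone, this is the first direct look at the double bond on its own, and the shift can be tied to its configuration alone because no other difference separates the pair: the fact that compounds 3 and 4 differ only in the configuration as drawn. With the two hydroxyl groups in place, the Z form therefore acts at smaller amounts, yet the E form still gives a real number, so the change weakens the effect without removing it.

Within the data shown here, whether the Z form keeps this edge with other groups in place of the two hydroxyl groups remains open, as the only pair that isolates the double bond carries those hydroxyl groups. From the compounds shown here alone, how a carboxylic acid in their place would behave, in either configuration, is also open.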